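Methoxy for methylsulfanyl in compound 4

This account rests on a few compounds, and the source may have more. Where it says the series, first, only, none or still open, it means among the compounds named here.

Within the data shown here, in a functional assay on DU-145 cells (Homo sapiens) for inhibition, read by trypan blue exclusion, with a stated time of 96 h (on this read-out higher numbers stand for weaker inhibition of growth and lower numbers for stronger inhibition of growth), compound 3 (`CSc1ccc(/C=C(\C(=O)c2ccc(Br)cc2)S(=O)(=O)c2ccc(C)cc2)cc1`) gives 1000 nM, the lowest of the three numbers so far, while compound 2 (`Cc1ccc(S(=O)(=O)/C(=C/c2ccc(Br)cc2)C(=O)c2ccc(Br)cc2)cc1`) gives 10000 nM. Compound 4 (`COc1ccc(/C=C(\C(=O)c2ccc(Br)cc2)S(=O)(=O)c2ccc(C)cc2)cc1`) differs from compound 3 in one place: methoxy in place of methylsulfanyl on an aromatic carbon. Among the measured compounds shown here, the one measured step at this place is a 10-fold lower number from compound 2 to compound 3 (1.00 log units; beyond the scatter), a modest step beyond the scatter, in which methylsulfanyl replaced bromo. For the measured compounds named here, no measured step involves methoxy directly. Compound 1 (`COc1ccc(/C=C(\C(=O)c2ccc(Br)cc2)S(=O)(=O)Cc2ccc(F)cc2)cc1`) also carries methoxy and gives 25000 nM, though it differs elsewhere too. A smaller step towards weaker inhibition is therefore expected, an estimated 3.0-fold higher number from compound 3 to compound 4 (0.48 log units; beyond the scatter). Compound 4 is expected at 3000 nM, within a range of 800 nM to 12000 nM.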

Compound 4, concentration for 50% growth inhibition: 1000 nM
Compound 4: the middle estimate sits 3.0-fold (0.48 log units) above what was measured; measured number inside the range.
By their numbers in this assay, from the lowest: compounds 3 and 4 (each within the scatter of the next); then compound 2; then compound 1.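

In this assay, methoxy and methylsulfanyl cannot be told apart at this place on the aromatic ring, with no change at the digits printed from compound 3 to compound 4 (within the scatter) and methoxy still well clear of bromo, at a 10-fold lower number from compound 2 to compound 4 (1.00 log units; beyond the scatter) in the same series. With methoxy held in place, 4-methylphenyl in place of 4-fluorobenzyl on the sulfonyl sulfur gives a 25-fold lower number from compound 1 to compound 4 (1.40 log units; beyond the scatter) and so marks the sulfonyl substituent as a second place that counts. Nothing available explains either result. Going by these compounds, whether an amine or a longer chain such as ethoxy at this place would hold the number seen for compound 3 and compound 4 remains open.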